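The compounds below may be only part of what the source reports. "The series", "measured", "known", "first", "only" and "open" are said of these compounds alone.

Working notes on the series. The shared core appears in compound 1 `COc1ccc(-c2cnn3c(NCc4ccccn4)cc(C)nc23)cc1`, compound 2 `Cc1cc(NCc2ccccn2)n2ncc(-c3ccc(N(C)C)cc3)c2n1` and compound 3 `Cc1cc(NCc2ccccn2)n2ncc(-c3ccsc3)c2n1`, each varied on one aromatic carbon. In a physicochemical assay for solubility, read by HPLC, using the shake flask method, measured as kinetic solubility, with a stated time of 2 h, at pH 7.4 (on this read-out higher numbers stand for higher solubility and lower numbers for lower solubility), compound 1 returns only a limit, < 5000 nM. Compound 2 likewise returns a limit, < 5000 nM, in this assay. Within the data shown here, compound 3 is the one member with an actual number, 9000 nM in this assay; the other two sit at the limit of < 5000 nM in this assay, at which 2 of the 3 values shown sit. The step of an at least 1.8-fold higher number from compound 1 to compound 3 (0.25 log units; that floor lies within the scatter) and the step of an at least 1.8-fold higher number from compound 2 to compound 3 (0.25 log units; that floor lies within the scatter) are thus known only as floors, while a step that the two limits leave unreadable from compound 1 to compound 2 cannot be read. Compound 4 `Cc1cc(NCc2ccccn2)n2ncc(-c3ccn(C)n3)c2n1` carries 1-methyl-1H-pyrazol-3-yl in place of thiophen-3-yl on an aromatic carbon. Among the measured compounds shown here, no measured step exchanges one five-membered ring for another, so the two floors into compound 3, both within scatter, are the only guide. The step of a 1.6-fold higher number from compound 3 to compound 4 (0.19 log units; within the scatter) is accordingly expected to stay within scatter. Compound 4 is estimated at 14000 nM, between 5000 nM and 40000 nM.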

Compound 4, solubility: 188000 nM
For compound 4 the middle estimate is 13-fold (1.13 log units) below the measured one, outside the stated range (above it).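

Exchanging thiophen-3-yl for 1-methyl-1H-pyrazol-3-yl gives a 21-fold higher number from compound 3 to compound 4 (1.32 log units; beyond the scatter) in this assay, so a change at this position now reads beyond the scatter, where the earlier floors did not. The same group in place of 4-(dimethylamino)phenyl gives an at least 37-fold higher number from compound 2 to compound 4 (1.57 log units; beyond the scatter), and in place of 4-methoxyphenyl it gives an at least 37-fold higher number from compound 1 to compound 4 (1.57 log units; beyond the scatter). These two steps are floors, each resting on a limit: the limit of < 5000 nM in this assay, at which 2 of the 4 values shown sit.

The compounds shown do not separate the effect of the ring nitrogens from that of the methyl on 1-methyl-1H-pyrazol-3-yl. Going by these compounds, how a pyrazolyl without the methyl, or a thiophene carrying an amine, would read in this assay stays open.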